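Trifluoromethyl on the Aryl Imine of a Hydrazone Series

The source may report more compounds than this note shows. Statements on the series, on what has been measured and on what is new or still open speak of the compounds shown alone.

Measured so far:
- compound 1, `CC(=O)/C(=N\Nc1ccccc1Cl)Nc1cccc(Cl)c1`: 417 nM; 417 nM (2 entries)
- compound 2, `CC(=O)/C(=N\c1ccccc1)NNc1ccccc1C`: 526 nM

Of the compounds shown here, two have been measured in an assay on isolated protein for binding affinity to corticotropin-releasing factor receptor 1 (Homo sapiens); on this read-out higher numbers stand for weaker inhibition and lower numbers for stronger inhibition. Compound 1 `CC(=O)/C(=N\Nc1ccccc1Cl)Nc1cccc(Cl)c1` gives 417 nM; 417 nM (2 entries), and compound 2 `CC(=O)/C(=N\c1ccccc1)NNc1ccccc1C` gives 526 nM. Among the compounds with values here, the two differ in more than one place, so no single structural step links them; their values sit within the usual scatter of each other, and neither can be called the more potent. Within the data shown here, compound 2 holds the only number recorded for it in this assay, with one further entry that gave no single number.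

Compound 3 `CC(=O)/C(=N\c1cccc(C(F)(F)F)c1)NNc1ccccc1C` has not yet been measured. It differs from compound 2 by trifluoromethyl in place of hydrogen on an aromatic carbon, a trifluoromethyl in place of hydrogen on an aromatic carbon, meta to a large group. Among the measured compounds shown here, no measured pair shows such a step here, so the expected effect rests on no direct precedent. A modest gain in affinity is expected rather than a loss, though the step may well stay within scatter. Compound 3 is estimated at 300 nM, with a range from 100 nM to 900 nM, corresponding to an expected step of a 1.8-fold lower number from compound 2 to compound 3 (0.24 log units; within the scatter).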

Compound 3, inhibition constant: 291 nM
The estimate for compound 3 lay 1.0-fold (0.01 log units) above the measured number; low and high end bracket the measured number.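

Within the data shown here, compound 3 provides the first step that differs in one place only, so the effect of a single change can now be read in this assay: putting trifluoromethyl in place of hydrogen on an aromatic carbon gives a 1.8-fold lower number from compound 2 to compound 3 (0.26 log units; within the scatter). The comparison of compound 1 and compound 2 could not show this, as those two differ in more than one place. At this position, meta to a large group, 4 heavy atoms can therefore enter without the read-out leaving the usual scatter, so this step cannot be called a real gain or loss in affinity, and no data on any other property are available to account for the outcome.

Still open, as far as these compounds go, is whether a different group on this same aromatic carbon, such as an amine, a carboxylic acid or a methoxy group, would shift the number beyond the scatter. It is also unknown whether trifluoromethyl would give a similar result on other carbons of this ring, or on the core of compound 1.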